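Tying Back the Imidazole Substituent of Compound 1 into a Ring

The source may report more compounds than this note shows. Statements on the series, on what has been measured and on what is new or still open speak of the compounds shown alone.

Compound 1 `CCn1ccnc1-c1cccc(Cl)c1CCc1cc(Br)ccc1OC`: 310 nM in an assay on isolated protein for binding affinity to Melanocortin receptor 4 (Homo sapiens); a lower number here means a stronger inhibitor, a higher number a weaker inhibitor
Compound 2 `COc1ccc(Br)cc1CCc1c(Cl)cccc1-c1nccn1C(C)C`: 670 nM in this assay
Compound 3 `CCC(C)n1ccnc1-c1cccc(Cl)c1CCc1cc(Br)ccc1OC`: 2500 nM in this assay

Compound 1 has the lowest number of the three, and both of its neighbours lie beyond the scatter from it: a 2.2-fold higher number from compound 1 to compound 2 (0.33 log units; beyond the scatter) and an 8.1-fold higher number from compound 1 to compound 3 (0.91 log units; beyond the scatter). Compound 4 `COc1ccc(Br)cc1CCc1c(Cl)cccc1-c1ncc2n1CCCC2` is derived from compound 1 by a group of 9 heavy atoms (7 carbon, 2 nitrogen; one five-membered aromatic ring with 2 hetero atoms, one six-membered non-aromatic ring with 1 hetero atom) in place of a group of 7 heavy atoms (5 carbon, 2 nitrogen; one five-membered aromatic ring with 2 hetero atoms), on an aromatic carbon. The measured steps that bear on this change are those adding carbon to the saturated chain carbon bound to the aromatic nitrogen, a 2.2-fold higher number from compound 1 to compound 2 (0.33 log units; beyond the scatter) and an 8.1-fold higher number from compound 1 to compound 3 (0.91 log units; beyond the scatter), both in the weakening direction and growing with the size of the addition. Since closing a ring is a different kind of enlargement from branching, a smaller rise is expected here: a 2.3-fold higher number from compound 1 to compound 4 (0.35 log units; beyond the scatter). Compound 4 is therefore estimated at 700 nM, with a range from 250 nM to 2000 nM.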

Compound 4, inhibition constant: 340 nM
Compound 4: middle estimate off by 2.1-fold (0.31 log units), on the high side, within the range that was stated.
By their numbers in this assay, from the lowest: compounds 1, 4 and 2 (each within the scatter of the next, the first and the last beyond it); then compound 3.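

In this assay, closing the imidazole substituent into a six-membered non-aromatic ring leaves binding unchanged within the scatter: a 1.1-fold higher number from compound 1 to compound 4 (0.04 log units; within the scatter). Added carbon at this position therefore need not weaken binding, since the ring is clearly apart from the larger open branched chain, a 7.4-fold lower number from compound 3 to compound 4 (0.87 log units; beyond the scatter), though it cannot be separated from the smaller branched chain, a 2.0-fold lower number from compound 2 to compound 4 (0.29 log units; within the scatter). Nothing given here explains this result. Still open, on these data alone, is whether a five-membered or seven-membered ring in this place, or an amine or hydroxyl group on the new ring, would keep this binding.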